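The source may report more compounds than this note shows. Statements on the series, on what has been measured and on what is new or still open speak of the compounds shown alone.

Measured compounds:
compound 1 `C=CC(C)(C)c1[nH]c2ccc(C[C@@H](O)C(C)(C)Cl)cc2c1/C=C1\NC(=O)[C@H](C)NC1=O` — 79000 nM
compound 2 `C=CC(C)(C)c1[nH]c2ccc(CC=C(C)C)cc2c1/C=C1\NC(=O)C(C)(OC)NC1=O` — 79000 nM
compound 3 `C=CC(C)(C)c1[nH]c2ccc(CC=C(C)C)c(CC=C(C)C)c2c1C[C@@H]1NC(=O)[C@H](C)NC1=O` — 623000 nM

In a functional assay (a lower number here means a stronger inhibitor, a higher number a weaker inhibitor), compound 1 gives 79000 nM, level with compound 2 at the digits shown, the two together giving the lowest numbers of the three; compound 3 gives 623000 nM, a clearly higher number than compound 1, beyond the scatter. Within the data shown here, no step between two measured compounds that differ in one place is available, so the change to the unmeasured compound 4 `C=CC(C)(C)c1[nH]c2ccc(C[C@@H](O)C(C)(C)O)cc2c1/C=C1\NC(=O)[C@H](C)NC1=O` has no measured precedent here. It differs from compound 1 as follows: hydroxy in place of chloro on a saturated chain carbon bound to three saturated chain carbons. Without a precedent, a small step in this assay is expected, if any, and not beyond the scatter in either direction. Compound 4 is therefore estimated at 100000 nM, within 30000 nM to 300000 nM, meaning an expected step of a 1.3-fold higher number from compound 1 to compound 4 (0.10 log units; within the scatter).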

Compound 4, half-maximal inhibitory concentration: 79000 nM
Compound 4: the middle estimate sits 1.3-fold (0.10 log units) above what was measured; measured number inside the range.
By their numbers in this assay, from the lowest: compounds 1, 2 and 4 (each within the scatter of the next); then compound 3.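

In this assay, among these compounds, hydroxy in place of chloro on a saturated chain carbon bound to three saturated chain carbons gives no change at the digits printed from compound 1 to compound 4 (within the scatter), the only measured step at this position. The 3-chloro-2-hydroxy-3-methylbutyl and 2,3-dihydroxy-3-methylbutyl chains therefore cannot be told apart in this assay. No available evidence bears on this result. The compounds shown leave open whether an amine or a fluoro group on this carbon, or a longer chain in place of the 2,3-dihydroxy-3-methylbutyl chain, would read differently.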